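The source may hold more compounds than are shown below. What is called first, only, known or untested is meant among the compounds shown, and "the series" means these compounds.

In an ADME assay on microsomes from liver (Rattus norvegicus, strain Sprague-Dawley) for metabolic stability, read by HPLC, using NADPH, with stated times of 5 min and 60 min, tested at 10 uM (on this read-out lower numbers stand for a shorter-lived compound and higher numbers for a longer-lived compound), three compounds have been measured so far:

compound 1 `CC(C)(C)c1ccc(C(=O)NCc2c(F)cc(NS(C)(=O)=O)cc2F)cc1` gives 2.42 h
compound 2 `CC(C)(C)c1ccc(C(=O)NCc2c(Cl)cc(NS(C)(=O)=O)cc2Cl)cc1` gives 1.37 h
compound 3 `CS(=O)(=O)Nc1ccc(CNC(=O)c2ccc(N3CCC3)cc2)c(Cl)c1` gives 2.62 h

Compound 3 sits at the upper edge of these three numbers, yet its gap to compound 1 and its gap to compound 2 both stay inside the usual scatter of this assay, so the three compounds cannot be ranked against one another on this read-out.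

Compound 4 `CC(F)(F)c1ccc(C(=O)NCc2ccc(NS(C)(=O)=O)cc2Cl)cc1` has not yet been measured. It differs from compound 3 in a single place: 1,1-difluoroethyl in place of azetidin-1-yl on an aromatic carbon. Going by the values given here, no measured pair carries this same change, so nothing here anchors its size. With the three known values lying so close together, only a small step, a 1.3-fold lower number from compound 3 to compound 4 (0.12 log units; within the scatter), is expected, not beyond the scatter in either direction. Compound 4 is therefore estimated at 2 h, with a range from 0.9 h to 4 h.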

Compound 4, half-life: 2.35 h
Compound 4: the middle estimate sits 1.2-fold (0.07 log units) below what was measured; the measured number falls inside the stated range.
By their numbers in this assay, from the lowest: compounds 2, 4, 1 and 3 (each within the scatter of the next).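

In this assay, putting 1,1-difluoroethyl in place of azetidin-1-yl on an aromatic carbon, para to a large group, gives a 1.1-fold lower number from compound 3 to compound 4 (0.05 log units; within the scatter). This is the first step in one place among these compounds, and it shows that the half-life does not separate these two groups at this position, although one has a ring and a nitrogen and the other has neither. Nothing available accounts for this result.

From the compounds shown here alone, whether a carboxylic acid or a longer alkyl chain at this position would move the half-life beyond the scatter remains open. So does whether the same change would behave alike on the core of compound 1.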